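Furanylmethyl to benzyl amide: expected cytotoxicity of compound 4

A few compounds are considered here, and "the series" means these few. Any claim that something is new, unique, unknown or untested is made for them only; others in the source may bear on it.

Measured so far:
compound 1, `N[C@H]1CC[C@H](Nc2c(C(=O)NCc3ccco3)nc(Br)c3cccnc23)CC1`: > 10000 nM (a limit of the assay, not a number)
compound 2, `O=C(NCc1ccc(F)cc1)c1nc(NCCO)c2cccnc2c1O`: > 20000 nM (a limit of the assay, not a number)
compound 3, `N[C@H]1CC[C@H](NC(=O)c2nc(Br)c3cccnc3c2NCc2ccc(F)cc2)CC1`: 6600 nM

In a functional assay on MDA-MB-435 cells (Homo sapiens) for cytotoxicity, read by MTT assay, with a stated time of 72 h (on this read-out higher numbers stand for weaker inhibition and lower numbers for stronger inhibition), compound 1 stands at a limit, namely (the limit of > 10000 nM in this assay, at which 1 of the 3 values shown sits), so no number is known for it. Compound 2 likewise stands at a limit, (the limit of > 20000 nM in this assay, at which 1 of the 3 values shown sits). Compound 3 is the only one of the three with a number, and that number sits in the weak range. Compound 1 therefore cannot be ranked against compound 3 beyond saying that it does not reach a measurable value.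

Compound 4, `N[C@H]1CC[C@H](Nc2c(C(=O)NCc3ccccc3)nc(Br)c3cccnc23)CC1`, differs from compound 1 in one place: phenyl in place of furan-2-yl on a saturated chain carbon bound to an amide-type nitrogen. For the measured compounds named here, no measured step accompanies this change. The expected step of a number no higher from compound 1 to compound 4 (the limit leaves the size open) is small, not beyond the usual scatter, and its direction is open. Compound 4 is estimated at 10000 nM, within a range from 3000 nM to 30000 nM, with a good chance that only a limit is reported again.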

Compound 4, half-maximal inhibitory concentration: 7000 nM
Compound 4: the middle estimate sits 1.4-fold (0.15 log units) above what was measured; low and high end bracket the measured number.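

In this assay compound 4 gives 7000 nM, so with phenyl in place of furan-2-yl on a saturated chain carbon bound to an amide-type nitrogen, this amide arm now carries a measured number on the shared core. Compound 1 stands at a limit, not a number: the limit of > 10000 nM in this assay, at which 1 of the 4 values shown sits. The change can therefore be read only as an at least 1.4-fold lower number from compound 1 to compound 4 (0.15 log units; that floor lies within the scatter), which leaves both the true size of the step and whether the swap matters at all unsettled.

The compounds shown hold only furan-2-yl and phenyl at this place, so two aromatic rings are all that can be set against each other. Going by these compounds, whether a pyridyl ring, a cyclohexyl ring or a longer chain ending in phenyl would move the value beyond the scatter remains open.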